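The source may report more compounds than this note shows. Statements on the series, on what has been measured and on what is new or still open speak of the compounds shown alone.

Three compounds have been measured in a functional assay on HCC1937 cells (Homo sapiens) for antiproliferative activity, read by CCK-8 assay, with a stated time of 72 h; a lower number here means a stronger inhibitor, a higher number a weaker inhibitor:

compound 1 `Cc1ccc(C(=O)Nc2cccc(-c3oc4cc(-c5ccc(F)cc5)ccc4c(=O)c3O)c2)cc1`, 7110 nM
compound 2 `O=C(Nc1cccc(-c2oc3cc(-c4ccc(F)cc4)ccc3c(=O)c2O)c1)c1ccc(C(F)(F)F)cc1`, 7350 nM
compound 3 `CCc1ccc(C(=O)Nc2cccc(-c3oc4cc(-c5ccc(F)cc5)ccc4c(=O)c3O)c2)cc1`, 13200 nM

Compound 3 carries the highest of the three numbers, yet its nearest neighbour is compound 2, at a 1.8-fold higher number from compound 2 to compound 3 (0.25 log units; within the scatter), and its furthest is compound 1, at a 1.9-fold higher number from compound 1 to compound 3 (0.27 log units; within the scatter); both gaps fall within the usual scatter, so compound 3 cannot be set apart from the other two on these numbers.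

Compound 4 `O=C(Nc1cccc(-c2oc3cc(-c4ccc(F)cc4)ccc3c(=O)c2O)c1)c1ccc([N+](=O)[O-])cc1` is the next member of the set. Against compound 3 the difference is nitro in place of ethyl on an aromatic carbon.

Among the measured compounds shown here, two measured steps bear on this change, since each also swaps the group on the same aromatic carbon of the benzamide ring: a 1.0-fold higher number from compound 1 to compound 2 (0.01 log units; within the scatter) and a 1.8-fold higher number from compound 2 to compound 3 (0.25 log units; within the scatter). Each lies within the scatter. For the measured compounds named here, three different groups at that position thus gave numbers that cannot be told apart, and no step toward a group like nitro has been measured. Compound 4 is therefore expected to show no step beyond the scatter, with a 1.3-fold lower number from compound 3 to compound 4 (0.12 log units; within the scatter).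

The estimate for compound 4 in this assay is 10000 nM, with a likely range from 4000 nM to 25000 nM.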

Compound 4, half-maximal inhibitory concentration: 5640 nM
Beside the measured number, compound 4's estimate is 1.8-fold (0.25 log units) above it; measured number inside the range.
By their numbers in this assay, from the lowest: compounds 4, 1, 2 and 3 (each within the scatter of the next, the first and the last beyond it).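

In this assay, among the compounds shown here, the aromatic carbon para to a large group now shows a step that can be read: nitro in place of ethyl gives a 2.3-fold lower number from compound 3 to compound 4 (0.37 log units; beyond the scatter) and stands as the only modest step at this position, where every earlier swap stayed within the scatter. Nitro still cannot be told apart from the two other groups, since replacing trifluoromethyl gives a 1.3-fold lower number from compound 2 to compound 4 (0.12 log units; within the scatter) and replacing methyl gives a 1.3-fold lower number from compound 1 to compound 4 (0.10 log units; within the scatter) in the same series, so only the ethyl and nitro compounds, at the two ends of the set, are separated, and the four groups do not fall into a clear order. Nothing available here explains why this one pair separates.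

The compounds shown leave open whether a group of another kind on this carbon, such as an amine, a carboxylic acid or a longer chain, would move the number further than this modest step. They also leave open whether nitro on another carbon of the same ring would give a similar result, as every group here sits at this single place.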